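The compounds below may be only part of what the source reports. "The series", "measured", "known", "first", "only" and "open" are said of these compounds alone.

Measured so far in an assay on cells for inhibition of Nicotinamide N-methyltransferase (Homo sapiens), with stated times of 10 min and 30 min; a higher number here means a weaker inhibitor, a lower number a stronger inhibitor:
compound 1, `COC(=O)c1cccc(CN(C[C@H]2O[C@@H](n3cnc4c(N)ncnc43)[C@H](O)[C@@H]2O)C(C)C)c1`: > 250000 nM
compound 2, `Nc1ncnc2c1ncn2[C@@H]1O[C@H](CN(CCCC(=O)O)Cc2cccc(C(=O)O)c2)[C@@H](O)[C@H]1O`: > 250000 nM

Compound 1 gives in this assay only a limit, > 250000 nM, and no number. Compound 2 likewise gives in this assay only a limit, > 250000 nM. Compound 2 therefore stands at the edge of what this assay reports, and the whole picture so far is the same edge: the limit of > 250000 nM in this assay, at which 2 of the 2 values shown sit. Going by the values given here, no step between measured compounds can be drawn, since the two values are not numbers and the two structures differ in more than one place.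

Compound 3, `CC(C)N(Cc1cccc(C(=O)O)c1)C[C@H]1O[C@@H](n2cnc3c(N)ncnc32)[C@H](O)[C@@H]1O`, is the next compound to be measured. It differs from compound 2 in a single spot: isopropyl in place of 3-carboxypropyl on an amine nitrogen. With compound 2 at the limit, a step from compound 2 to compound 3 can only go toward stronger inhibition or stay within the scatter at the limit; the two shown values give no ground for saying which. The estimate for compound 3 is therefore a cautious one, the expected step from compound 2 to compound 3 being an at least 3.1-fold lower number from compound 2 to compound 3 (0.49 log units; beyond the scatter), and compound 3 is expected to give about 80000 nM, within roughly 5000 nM to 250000 nM, with a real chance that this assay again reports only a limit.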

Compound 3, half-maximal inhibitory concentration: > 250000 nM
Compound 3 ended at the assay's limit (the forecaster's own chance of this, stated with the estimate: 50%); at least 3.1-fold (0.49 log units) between middle value and limit.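

In this assay compound 3 gives only a limit, > 250000 nM. The steps to compound 3 from compound 2 and from compound 1 therefore cannot be read. The picture stays at one edge: the limit of > 250000 nM in this assay, at which 3 of the 3 values shown sit. The compounds shown leave open how compound 1, compound 2 and compound 3 rank against one another, and whether any change on the shared core gives a readable number in this assay.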